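The compounds below may be only part of what the source reports. "The series", "measured", "known", "first", "only" and "open" are said of these compounds alone.

Compound 1, `CN[C@@H](CC(C)C)CN(C(=O)[C@@H]1C[C@H]1c1ccccc1)c1ccc(-c2ccccc2)cc1`: 2 nM
Compound 2, `CO[C@H](C)[C@H](N)CN(C(=O)[C@@H]1C[C@H]1c1ccccc1)c1ccc(-c2ccccc2)cc1`: 0.68 nM
Compound 3, `CC[C@H](C)[C@H](N)CN(C(=O)[C@@H]1C[C@H]1c1cccc(OC)c1)c1ccc(-c2ccccc2)cc1`: 3000 nM

Of the compounds shown here, three have been measured in a functional assay for agonist activity at G protein-coupled receptor 88 (Homo sapiens), read by HTRF and cAMP accumulation; on this read-out lower numbers stand for an effect already at smaller amounts and higher numbers for an effect only at larger amounts of compound. Compound 3 gives the highest of the three numbers: next to it stands compound 1 with 2 nM, furthest away compound 2 with 0.68 nM, so compound 3 sits far from both. For the measured compounds named here, the one step measured within one site, a 2.9-fold lower number from compound 1 to compound 2 (0.47 log units; beyond the scatter), concerns the saturated chain carbon bound to the amide-type nitrogen and is modest.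

Compound 4, `CC[C@H](C)[C@H](N)CN(C(=O)[C@@H]1C[C@H]1c1ccoc1)c1ccc(-c2ccccc2)cc1`, differs from compound 3 at another site: furan-3-yl in place of 3-methoxyphenyl on a saturated ring carbon. Going by the values given here, no measured step bears on this change; compounds 1 and 2 carry phenyl at that position but also differ from compound 3 elsewhere, so their values show only that they are far lower. With nothing to guide the direction, the step of a 1.3-fold higher number from compound 3 to compound 4 (0.12 log units; within the scatter) is expected to be small, in either direction, and compound 4 is estimated at 4000 nM, within 700 nM to 25000 nM.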

Compound 4, half-maximal effective concentration: 580 nM
Beside the measured number, compound 4's estimate is 6.9-fold (0.84 log units) above it; the whole stated range lies above it.
By their numbers in this assay, from the lowest: compound 2; then compound 1; then compound 4; then compound 3.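

For the compounds shown here, at the saturated ring carbon of the three-membered ring, the group clearly influences the read-out in this assay: furan-3-yl in place of 3-methoxyphenyl gives a 5.2-fold lower number from compound 3 to compound 4 (0.71 log units; beyond the scatter) and is the first measured step at this site. By the counts, both groups carry one hydrogen-bond acceptor and no hydrogen-bond donor, so this step involves a change of aromatic ring and the loss of the methoxy group without a change in those counts. Nothing available accounts for the size or direction of this step.

On these data alone, it remains open whether the step comes from the furan-3-yl ring itself or from the loss of the methoxy group; a plain phenyl, a thiophene or a pyridine on the core of compound 3 would separate the two. Also open, as far as these compounds go, is whether the same change would carry over to the cores of compound 1 and compound 2.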